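This account rests on a few compounds, and the source may have more. Where it says the series, first, only, none or still open, it means among the compounds named here.

In an ADME assay on THP-1 cells (Homo sapiens) for cytotoxicity, read by MTT assay, with a stated time of 72 h (on this read-out lower numbers stand for stronger inhibition and higher numbers for weaker inhibition), compound 2 (`O=C(O)c1ccc(/C=C/C(=O)c2c(O)c3ccccc3[nH]c2=O)cc1`) stands at > 50000 nM, a limit and not a number. Compound 1 (`O=C(/C=C/C=C/c1ccccc1)c1c(O)c2ccccc2[nH]c1=O`) gives > 50000 nM, also a limit. Compound 3 (`CC(/C=C/C(=O)c1c(O)c2ccccc2[nH]c1=O)=C\c1ccccc1`) gives > 50000 nM, likewise a limit. The series thus rests at the limit of > 50000 nM in this assay, at which 3 of the 3 values shown sit. Compound 4 (`COc1ccc(/C=C/C(=O)c2c(O)c3ccccc3[nH]c2=O)cc1`) follows from compound 2 by methoxy in place of carboxy on an aromatic carbon, para to a large group. Going by the values given here, the only measured step, a step that the two limits leave unreadable from compound 1 to compound 3, is a different change and gives no size to carry over, so no step beyond the scatter is expected in this assay. Compound 4 is expected to report as a limit too. For compound 4 the estimate is 50000 nM, with an expected range from 20000 nM to 100000 nM. The estimated step is a number no higher from compound 2 to compound 4 (the limit leaves the size open).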

Compound 4, half-maximal inhibitory concentration: > 50000 nM
Compound 4: only a limit was reported (the forecaster's own chance of this, stated with the estimate: 70%); the middle value lies on the limit itself.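

Compound 4 gives only a limit in this assay, like compound 1, compound 2 and compound 3, so no new step can be read: the limit of > 50000 nM in this assay, at which 4 of the 4 values shown sit.

The compounds shown leave open whether any of these changes shifts cytotoxicity at all.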